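Hydroxamate-pyrazole aminopyrimidines: anilide swap from compound 1

The source may hold more compounds than are shown below. What is called first, only, known or untested is meant among the compounds shown, and "the series" means these compounds.

Measured so far:
- compound 1 `O=C(CCCCCn1cc(Nc2ncc(Cl)c(Nc3ccccc3Cl)n2)cn1)NO`: 310 nM
- compound 2 `O=C(CCCCCCn1cc(Nc2ncc(Cl)c(Nc3ccc(Cl)cc3)n2)cn1)NO`: 100 nM
- compound 3 `O=C(CCCCCCn1cc(Nc2ncc(C(F)(F)F)c(Nc3ccc(F)cc3)n2)cn1)NO`: "not determined" (no result reported)

In a functional assay on Jurkat cells (Homo sapiens) for antiproliferative activity, read by MTT assay, with a stated time of 48 h (on this read-out higher numbers stand for weaker inhibition and lower numbers for stronger inhibition), compound 1 gives 310 nM, the higher of the two numbers recorded; compound 2 stands at 100 nM, a gap beyond the scatter. For compound 3 no result in this assay was reported. Compound 2 differs from compound 1 in more than one place, so its lower number is not tied to a single change.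

Compound 4 `O=C(CCCCCn1cc(Nc2ncc(Cl)c(Nc3ccc(F)cc3)n2)cn1)NO` has not been measured. It differs from compound 1 in one place only: 4-fluorophenyl in place of 2-chlorophenyl on a nitrogen on an aromatic ring. Among the measured compounds shown here, no single-change step between measured compounds is available for this series, so the direction is inferred from compound 2, whose lower number 100 nM is the only reference with a different substituent on the same ring. A small downward step in the number is expected, a 1.6-fold lower number from compound 1 to compound 4 (0.21 log units; within the scatter), likely at or near the edge of the scatter rather than clearly beyond it. Compound 4 is estimated at 190 nM, within a range of 70 nM to 500 nM.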

Compound 4, half-maximal inhibitory concentration: 60 nM
The estimate for compound 4 lay 3.2-fold (0.50 log units) above the measured number; measured number below the stated range.
By their numbers in this assay, from the lowest: compounds 4 and 2 (each within the scatter of the next); then compound 1.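

In this assay, among the compounds shown here, the change to 4-fluorophenyl from 2-chlorophenyl on a nitrogen on an aromatic ring gives a 5.2-fold lower number from compound 1 to compound 4 (0.71 log units; beyond the scatter) and is the first single-change step. It shows that the number responds to the aryl group at this position with the rest of compound 1 held fixed, which compound 2 could not show, as it differs from compound 1 in more than one place. Both the halogen and its ring position change in this swap, and no supporting data on the step are available.

Open, on these data alone, is whether the halogen or its ring position carries the step: 2-fluorophenyl and 4-chlorophenyl on the chain of compound 1 would separate the two. Also open, as far as these compounds go, is how plain phenyl or 4-methoxyphenyl would read at this nitrogen.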